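The compounds below may be only part of what the source reports. "The series", "measured", "known", "first", "only" and "open" are said of these compounds alone.

In a functional assay on Sf9 cells for antagonist activity at histamine H2 receptor (Homo sapiens), with stated times of 2 min and 20 min (on this read-out higher numbers stand for higher potency (the scale is a negative logarithm) and lower numbers for lower potency), three compounds of one series have been measured. Compound 1 `CC(CC(=O)/N=C(\N)NCCCc1ccc(CN(C)C)o1)c1ccccc1` gives 6.52. Compound 2 `CN(C)Cc1ccc(CCCN/C(N)=N/C(=O)CC(c2ccccc2)c2ccccc2)o1` gives 7.03. Compound 3 `CC(CC(=O)/N=C(\N)NCCCc1ncc[nH]1)c1ccccc1` gives 5.3, the lowest of the three.

Two steps connect them. Compound 2 differs from compound 1 by phenyl in place of methyl on a saturated chain carbon bound to an aromatic carbon and a saturated chain carbon, and this change brought a number 0.51 log units higher from compound 1 to compound 2 (beyond the scatter). Compound 3 differs from compound 1 in its core, by 1H-imidazol-2-yl in place of 5-((dimethylamino)methyl)furan-2-yl on a saturated chain carbon, three bonds along the chain from an amine nitrogen, and that change brought a number 1.22 log units lower from compound 1 to compound 3 (beyond the scatter).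

Compound 4 `N/C(=N\C(=O)CC(c1ccccc1)c1ccccc1)NCCCc1ncc[nH]1` has not yet been measured in this assay. It carries the core of compound 3 and differs from compound 3 by phenyl in place of methyl on a saturated chain carbon bound to an aromatic carbon and a saturated chain carbon. This is the same change that separates compound 2 from compound 1, made at a place described in the same words, so it is the same change on a different core; among the compounds shown it occurs twice in all.

The expectation for compound 4 rests on that parallel. Because the same change gave a number 0.51 log units higher from compound 1 to compound 2 (beyond the scatter), compound 4 is expected to stand above compound 3 by a step of about a number 0.50 log units higher from compound 3 to compound 4 (beyond the scatter). Whether the core of compound 3 carries this change as the core of compound 1 did is not known from the data, so the estimate is held loosely. Compound 4 is therefore estimated at 5.8, with a likely range from 5.3 to 6.3.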

Compound 4, negative logarithm of the antagonist equilibrium constant: 6.13
Beside the measured number, compound 4's estimate is 0.33 log units below it; the measured number falls inside the stated range.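

In this assay, phenyl in place of methyl on the other core gave a number 0.83 log units higher from compound 3 to compound 4 (beyond the scatter), and beside the earlier step the change carried over in direction and, within the scatter, in size: the same change on two cores in this assay, a number 0.51 log units higher (beyond the scatter) from compound 1 to compound 2 and a number 0.83 log units higher (beyond the scatter) from compound 3 to compound 4, 0.32 log units apart, within the scatter of two such steps. With phenyl in place of methyl already present, 1H-imidazol-2-yl in place of 5-((dimethylamino)methyl)furan-2-yl gave a number 0.90 log units lower from compound 2 to compound 4 (beyond the scatter), and this exchange also held up beside its counterpart: the same change on two cores in this assay, a number 1.22 log units lower (beyond the scatter) from compound 1 to compound 3 and a number 0.90 log units lower (beyond the scatter) from compound 2 to compound 4, 0.32 log units apart, within the scatter of two such steps. Together the four compounds show that, on this read-out, each change kept its direction and its size within the scatter whichever form of the other place it met, but they form only one set of two cores and two groups, so they do not show that either change would carry to a further core or to another read-out.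

The compounds shown leave open how the step would run with a group other than methyl or phenyl on that saturated chain carbon, such as a hydrogen, a cyclohexyl or a benzyl. They also leave open whether the two changes would stay this consistent with a longer chain in place of the present one, or with an amine other than the dimethylamino group on the furan.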